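This account rests on a few compounds, and the source may have more. Where it says the series, first, only, none or still open, it means among the compounds named here.

Measured so far:
Compound 1, `Cc1ccccc1-c1nc2c(NC3CCCC3)ncnc2n1C`. In a functional assay on CHO cells for antagonist activity at adenosine receptor A2b (Homo sapiens), read by 33P incorporation, with a stated time of 20 min (on this read-out higher numbers stand for weaker inhibition and lower numbers for stronger inhibition), compound 1 gives > 30000 nM, which is a limit of the assay and not a number.
Compound 2, `Cn1c(-c2ccc(Cl)cc2)nc2c(NC3CCCC3)ncnc21`. In this assay compound 2 gives > 30000 nM, again a limit of the assay and not a number.

Compound 2 therefore stands at the limit of > 30000 nM in this assay, at which 2 of the 2 values shown sit; nothing more precise is known about its strength. Among the measured compounds shown here, the one measured step, a step that the two limits leave unreadable from compound 1 to compound 2, joins two such limits, so its size cannot be read either. Compound 3, `Cn1c(-c2ccccc2)nc2c(NC3CCCC3)ncnc21`, differs from compound 2 by hydrogen in place of chloro on an aromatic carbon. For the measured compounds named here, no measured step bears directly on a change of this kind, and the only step at hand is itself unreadable, so the expectation rests on the fact that both measured compounds sit at the limit. Compound 3 is expected to remain weak, with a step of a number no higher from compound 2 to compound 3 (the limit leaves the size open) that is estimated to stay within the scatter. The estimate for compound 3 in this assay is 30000 nM, with a range from 5000 nM to 100000 nM, and a good chance that only a limit and no number is reported.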

Compound 3, inhibition constant: 8510 nM
For compound 3 the middle estimate is 3.5-fold (0.55 log units) above the measured one, and the stated range covers the measured number.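

Plain phenyl gives the first real number among these compounds in this assay, so this part of the molecule can change the result and is not simply inactive whatever is placed there. Taking away the chloro from the 4-chlorophenyl gives an at least 3.5-fold lower number from compound 2 to compound 3 (0.54 log units; beyond the scatter), and going from the 2-methylphenyl to plain phenyl gives an at least 3.5-fold lower number from compound 1 to compound 3 (0.54 log units; beyond the scatter). On this shared core, therefore, each of the two substituted rings goes with a weaker result than the unsubstituted phenyl, and the true size of each step stays open because compound 1 and compound 2 each rest on a limit of the assay and not on a number: the limit of > 30000 nM in this assay, at which 2 of the 3 values shown sit.

From the compounds shown here alone, the step between compound 1 and compound 2 cannot be read, so it remains unknown whether the chloro or the methyl costs more. Also open, going by these compounds, is whether any group on this ring can improve on plain hydrogen, for example a fluoro, a methoxy, a hydroxyl or an amine, and whether the outcome depends on where on the ring such a group sits.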